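Cytotoxicity series: threonine-type analogue of compound 3

This account rests on a few compounds, and the source may have more. Where it says the series, first, only, none or still open, it means among the compounds named here.

Measured compounds:
compound 1, `C=C1[C@H](C)CCC[C@]1(C)CC/C(C)=C/CC1=C(O)C(=O)C=C(N[C@@H](CO)C(=O)O)C1=O`: > 10 ug/mL
compound 2, `C=C1[C@H](C)CCC[C@]1(C)CC/C(C)=C/CC1=C(O)C(=O)C=C(OC)C1=O`: > 10 ug/mL
compound 3, `CC1=CCC[C@](C)(CC/C(C)=C/CC2=C(O)C(=O)C=C(N[C@@H](CO)C(=O)O)C2=O)[C@@H]1C`: > 10 ug/mL

In an ADME assay on KB cells (Homo sapiens) for cytotoxicity, with a stated time of 48 h (on this read-out lower numbers stand for stronger inhibition and higher numbers for weaker inhibition), compound 1 gives only a limit, > 10 ug/mL. Compound 2 likewise gives a limit, > 10 ug/mL. Compound 3 also stands at a limit, > 10 ug/mL; all three values sit at the limit of > 10 ug/mL in this assay, at which 3 of the 3 values shown sit. Both measured steps, a step that the two limits leave unreadable from compound 1 to compound 2 and a step that the two limits leave unreadable from compound 1 to compound 3, are therefore unreadable, and neither bears usefully on compound 4, `CC1=CCC[C@](C)(CC/C(C)=C/CC2=C(O)C(=O)C=C(N[C@H](C(=O)O)[C@@H](C)O)C2=O)[C@@H]1C`. Compound 4 differs from compound 3 by methyl in place of hydrogen on a saturated chain carbon bound to an oxygen on a saturated carbon and a saturated chain carbon. Among the compounds with values here, no measured step shows a change of this kind, so no size or direction is expected beyond the scatter; the step that the limit leaves unreadable from compound 3 to compound 4 is estimated to be flat. Compound 4 is expected at about 20 ug/mL, within 10 ug/mL to 50 ug/mL, most likely again reported as a limit.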

Compound 4, half-maximal inhibitory concentration: > 10 ug/mL
Compound 4: a limit, no number; the forecaster's own chance of this, stated with the estimate: 85%; the middle value does not contradict the limit.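

Compound 3 and compound 4 both give only a limit, so no step between them can be read: the limit of > 10 ug/mL in this assay, at which 4 of the 4 values shown sit.

The compounds shown leave open how strongly any of them acts in this assay, and whether methyl in place of hydrogen changes anything there.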